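The source may hold more compounds than are shown below. What is called first, only, known or untested is meant among the compounds shown, and "the series" means these compounds.

Among the compounds with values here, compound 2 `CN(Cc1cc(C(F)(F)F)cc(C(F)(F)F)c1)C(=O)c1c(CO)nc2ccccc2c1-c1ccccc1` is the weaker of the two members measured so far: in an in vitro assay on UC11MG cells for binding affinity to Substance-P receptor (Homo sapiens), read by radioligand binding (a higher number here means a weaker inhibitor, a lower number a stronger inhibitor), compound 2 gives 16 nM, whereas compound 1 `CN(Cc1cc(C(F)(F)F)cc(C(F)(F)F)c1)C(=O)c1cnc2ccccc2c1-c1ccccc1` gives 0.03 nM. Within the data shown here, the only step recorded, a 530-fold higher number from compound 1 to compound 2 (2.73 log units; beyond the scatter), is the introduction of the hydroxymethyl group onto the shared core, and it stands out as a large loss. Compound 3 `COCc1nc2ccccc2c(-c2ccccc2)c1C(=O)N(C)Cc1cc(C(F)(F)F)cc(C(F)(F)F)c1` is next in line. It differs from compound 2 by methyl in place of hydrogen on an oxygen on a saturated carbon. Among the measured compounds shown here, no measured step concerns a change at the oxygen of that hydroxymethyl group, so the large step from compound 1 to compound 2 does not transfer directly; it only shows that this region of the core is sensitive to substitution. For the measured compounds named here, with no direct precedent, the expected step of a 1.3-fold higher number from compound 2 to compound 3 (0.10 log units; within the scatter) is taken as small and without a firm direction. For compound 3 the estimate in this assay is 20 nM, with a range from 3 nM to 150 nM.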

Compound 3, half-maximal inhibitory concentration: 11 nM
Compound 3: middle estimate off by 1.8-fold (0.26 log units), on the high side, within the range that was stated.
By their numbers in this assay, from the lowest: compound 1; then compounds 3 and 2 (each within the scatter of the next).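

In this assay, exchanging the hydroxymethyl group for methoxymethyl stays within the scatter (a 1.5-fold lower number from compound 2 to compound 3 (0.16 log units; within the scatter)), so the hydrogen on that oxygen is not required to keep the number at this level. Methoxymethyl in place of hydrogen on the aromatic carbon also gives a large loss (a 370-fold higher number from compound 1 to compound 3 (2.56 log units; beyond the scatter)), which shows that the loss is not peculiar to hydroxymethyl but is shared by these two oxygen-bearing groups. Nothing available accounts for the loss at this position.

Still open, on these data alone, is whether the loss follows any substituent on this aromatic carbon or only those carrying an oxygen, which a plain methyl or an aminomethyl group would test. A carboxylic acid or a longer ether chain at the same carbon would show how far the number moves beyond these two groups.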